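A few compounds are considered here, and "the series" means these few. Any claim that something is new, unique, unknown or untested is made for them only; others in the source may bear on it.

Measured in a functional assay on U-373MG ATCC cells (Homo sapiens) for inhibition, read by MTT assay, with a stated time of 72 h; a lower number here means a stronger inhibitor, a higher number a weaker inhibitor:
- compound 1 `CC1(C)CC(NC(=S)Nc2cccc([N+](=O)[O-])c2)c2cc(Br)ccc2O1`: 4000 nM
- compound 2 `CC1(C)CC(NC(=S)Nc2cccc(Cl)c2)c2cc(Br)ccc2O1`: 8000 nM

Only these two numbers are available, and compound 2, at 8000 nM, lies within the scatter of compound 1. Compound 3 `CC1(C)CC(NC(=S)Nc2ccc(Cl)cc2)c2cc(Br)ccc2O1` has not yet been measured in this assay. It has the same atoms as compound 2, joined differently: 4-chlorophenyl in place of 3-chlorophenyl on an amide-type nitrogen. Within the data shown here, the one measured step that bears on this is a 2.0-fold higher number from compound 1 to compound 2 (0.30 log units; within the scatter), with chloro in place of nitro on an aromatic carbon, and it stays within the scatter. Among the measured compounds shown here, no measured step compares 4-chlorophenyl with 3-chlorophenyl directly, so the evidence is thin. No step beyond the scatter is expected, in either direction. The estimated change is a 1.3-fold lower number from compound 2 to compound 3 (0.12 log units; within the scatter). For compound 3, the expected value is 6000 nM, with an estimated range of 2500 nM to 15000 nM.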

Compound 3, half-maximal inhibitory concentration: 7000 nM
Compound 3: the middle estimate sits 1.2-fold (0.07 log units) below what was measured; the range from low to high includes it.
By their numbers in this assay, from the lowest: compounds 1, 3 and 2 (each within the scatter of the next).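

In this assay, 4-chlorophenyl in place of 3-chlorophenyl on the amide-type nitrogen gives a 1.1-fold lower number from compound 2 to compound 3 (0.06 log units; within the scatter), so this assay does not separate these two chlorophenyl groups. The earlier step exchanged one substituent for another, chloro in place of nitro, whereas this one keeps the same atoms and changes only how they are joined, and it also stays within the scatter. No independent evidence bears on this result. 

The compounds shown leave open whether a methoxy group or a dimethylamino group on the phenyl ring would give a step beyond the scatter. They also leave open whether a carbonyl in place of the thiocarbonyl, or a change to the shared core, would alter the numbers in this assay.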